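This account rests on a few compounds, and the source may have more. Where it says the series, first, only, none or still open, it means among the compounds named here.

Compound 2 `Cc1nn(Cc2nc3ccccc3n2CCCCO)c2ccccc12` was tested in an ADME assay on HEp-2 cells (Homo sapiens) for cytotoxicity, read by CCK-8 assay, with a stated time of 5 days; on this read-out higher numbers stand for lower toxicity in this test and lower numbers for higher toxicity in this test. In this assay compound 2 gives > 100000 nM, which is a limit of the assay rather than a measured number. Among the measured compounds shown here, the only other value comes from compound 1 `N#Cc1cn(Cc2nc3ccccc3n2CCCCO)c2ccccc12`, and in this assay compound 1 gives > 100000 nM, again a limit and not a number. Both values therefore sit at the same edge of what the test can report: the limit of > 100000 nM in this assay, at which 2 of the 2 values shown sit. For the measured compounds named here, no step between two measured compounds is available from these two limits.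

Compound 3 `OCCCCn1c(Cn2ncc3ccccc32)nc2ccccc21` is the next member. Compared with compound 2 it carries hydrogen in place of methyl on an aromatic carbon, that is, hydrogen in place of methyl on an aromatic carbon. Going by the values given here, the two measured compounds give no step to lean on, so only the small size of this change speaks, and no shift beyond the usual scatter is expected.

For compound 3 the expected value is 100000 nM, within a range from 50000 nM to 300000 nM. This estimate corresponds to an expected step of a number no higher from compound 2 to compound 3 (the limit leaves the size open), and most likely the assay will again report only a limit.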

Compound 3, half-maximal cytotoxic concentration: > 100000 nM
Compound 3 was reported as a limit (the forecaster's own chance of this, stated with the estimate: 80%); the middle value lies on the limit itself.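

No step from compound 2 to compound 3 can be read in this assay, because both results are limits and not numbers: the limit of > 100000 nM in this assay, at which 3 of the 3 values shown sit.

The compounds shown leave open whether hydrogen in place of methyl on an aromatic carbon changes the result in this assay, and at what concentration any of the three compounds would become toxic in this test.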